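Hydroxy for amino on a sulfonamide-linked aryl ring

The compounds below may be only part of what the source reports. "The series", "measured", "known", "first", "only" and "open" are said of these compounds alone.

Compound 1 `COc1cc(OC)c(/C=C/S(=O)(=O)Nc2ccc(OC)c(O)c2)c(OC)c1`: 15 nM
Compound 2 `COc1cc(OC)c(/C=C/S(=O)(=O)Nc2ccc(OC)c(N)c2)c(OC)c1`: 3 nM
Compound 3 `COc1ccc(NS(=O)(=O)/C=C/c2c(OC)cc(OCCCC(=O)O)cc2OC)cc1N`: 10000 nM

The three measured compounds were tested in a functional assay on K562 cells (Homo sapiens) for cytotoxicity, read by trypan blue exclusion, with a stated time of 96 h; a lower number here means a stronger inhibitor, a higher number a weaker inhibitor. Compound 2 gives the lowest number of the three, and compound 3 the highest.

Two single changes connect them. The first is hydroxy in place of amino on an aromatic carbon, which gave a 5.0-fold higher number from compound 2 to compound 1 (0.70 log units; beyond the scatter). The second is 2-carboxyethyl in place of hydrogen on a saturated chain carbon bound to an oxygen on an aromatic ring, which gave a 3300-fold higher number from compound 2 to compound 3 (3.52 log units; beyond the scatter); this is also how the core of compound 3 differs from the core of compound 2.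

Compound 4 `COc1ccc(NS(=O)(=O)/C=C/c2c(OC)cc(OCCCC(=O)O)cc2OC)cc1O` has not yet been measured in this assay. It differs from compound 3 by hydroxy in place of amino on an aromatic carbon. Among the measured compounds shown here, this is the same change as the one made from compound 2 to compound 1; the place of the change reads the same word for word in both cases, so the two steps can be set side by side.

For the measured compounds named here, on that footing, the step from compound 3 to compound 4 is expected to be a 3.0-fold higher number from compound 3 to compound 4 (0.48 log units; beyond the scatter), modest and in the same direction as the measured step from compound 2 to compound 1, which is the only guide available here; it rests on the one measured pair a 5.0-fold higher number from compound 2 to compound 1 (0.70 log units; beyond the scatter) and on the value of compound 3, 10000 nM. Compound 4 is therefore estimated at 30000 nM, with a likely range from 8000 nM to 100000 nM.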

Compound 4, half-maximal inhibitory concentration: 10000 nM
For compound 4 the middle estimate is 3.0-fold (0.48 log units) above the measured one, within the range that was stated.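

In this assay, hydroxy in place of amino on an aromatic carbon did not behave alike on the two cores: on the core bearing the carboxylic acid chain it gave no change at the digits printed from compound 3 to compound 4 (within the scatter), and set beside the earlier step the two disagree: the same change on two cores in this assay, a 5.0-fold higher number (0.70 log units; beyond the scatter) from compound 2 to compound 1 and no change at the digits printed (within the scatter) from compound 3 to compound 4, 5.0-fold (0.70 log units) apart, beyond the scatter of two such steps

The chain change, 2-carboxyethyl in place of hydrogen on a saturated chain carbon bound to an oxygen on an aromatic ring, gave a 670-fold higher number from compound 1 to compound 4 (2.82 log units; beyond the scatter), so it is large with hydroxy as well as with amino, though its size is not the same in the two cases: the same change on two cores in this assay, a 3300-fold higher number (3.52 log units; beyond the scatter) from compound 2 to compound 3 and a 670-fold higher number (2.82 log units; beyond the scatter) from compound 1 to compound 4, 5.0-fold (0.70 log units) apart, beyond the scatter of two such steps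

Among the compounds shown here, these results show that the size of a step measured on one core could not be carried unchanged to the other, but with only two pairs for each change they give no rule for other cores and do not show what lies behind the difference.

The compounds shown leave open how the hydroxy and amino exchange would read on a core with a shorter or longer chain in place of the one in compound 3. They also leave open whether an ester, an amide or an amine in place of the carboxylic acid would give a step like those seen here.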